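This account rests on a few compounds, and the source may have more. Where it says the series, first, only, none or still open, it means among the compounds named here.

Two compounds of this series carry numbers. In an assay on isolated protein for binding affinity to corticotropin-releasing factor receptor 1 (Homo sapiens) (a lower number here means a stronger inhibitor, a higher number a weaker inhibitor), compound 1 `CCCN(CCC)c1cc(C)nc2c(-c3ncc(C(F)(F)F)cc3Cl)c(C)nn12` gives 1.2 nM. Compound 2 `CCCN(CCC)c1cc(C)nc2c(-c3ncc(N)cc3C)c(C)nn12` gives 85 nM in this assay, the higher of the two numbers; its nearest neighbour is compound 1, separated by a gap beyond the scatter. Compound 3 `CCCN(CCC)c1cc(C)nc2c(-c3ncc(O)cc3C)c(C)nn12` is not yet measured; it differs from compound 2 by hydroxy in place of amino on an aromatic carbon. Going by the values given here, no measured pair shows this change, so its size is unknown from these data. The expected 1.2-fold higher number from compound 2 to compound 3 (0.07 log units; within the scatter) is small, within the scatter, with no preferred direction. For compound 3 the estimate in this assay is 100 nM, ranging from 30 nM to 400 nM.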

Compound 3, inhibition constant: 530 nM
The estimate for compound 3 lay 5.3-fold (0.72 log units) below the measured number, and the stated range ends below it.
By their numbers in this assay, from the lowest: compound 1; then compound 2; then compound 3.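

Hydroxy in place of amino on this aromatic carbon, two atoms from the ring nitrogen, gives a 6.2-fold higher number from compound 2 to compound 3 (0.79 log units; beyond the scatter) in this assay. The two groups match in heavy-atom count and in hydrogen-bond donor and acceptor count, so these counts alone do not fix the number at this position. No available measurement accounts for the step.

On these data alone, whether a methoxy or a dimethylamino group on this carbon would stand nearer compound 2 or compound 3 remains open. As far as these compounds go, compound 1 differs from both in more than one place, so the separate contributions of its trifluoromethyl and chloro groups also remain open.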